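Cytotoxicity of biaryl nitro alcohols after a distal substituent swap

A few compounds are considered here, and "the series" means these few. Any claim that something is new, unique, unknown or untested is made for them only; others in the source may bear on it.

Measured so far:
compound 1, `COc1cc(CC(O)c2ccc(-c3ccc(C=O)cc3)cc2)c([N+](=O)[O-])cc1OC`, > 245000 nM
compound 2, `COc1cc(CC(O)c2ccc(-c3ccc(C)cc3)cc2)c([N+](=O)[O-])cc1OC`, 4700 nM
compound 3, `COc1cc(CC(O)c2ccc(-c3ccc(F)cc3)cc2)c([N+](=O)[O-])cc1OC`, 4500 nM

In an ADME assay on HeLa Rh cells (Homo sapiens) for cytotoxicity, read by microscopy (on this read-out lower numbers stand for higher toxicity in this test and higher numbers for lower toxicity in this test), compound 1 gives only a limit, > 245000 nM, and no number. Compound 2 stands highest of the two real numbers in this assay; compound 3 gives 4500 nM, and the step of a 1.0-fold lower number from compound 2 to compound 3 (0.02 log units; within the scatter) lies within the scatter, so the two cannot be ordered. The step of an at least 52-fold lower number from compound 1 to compound 2 (1.71 log units; beyond the scatter) is large, as is an at least 54-fold lower number from compound 1 to compound 3 (1.73 log units; beyond the scatter), and both run from the formyl-bearing compound to a compound lacking it.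

Compound 4, `COc1cc(CC(O)c2ccc(-c3cccc(CO)c3)cc2)c([N+](=O)[O-])cc1OC`, is not yet measured. It differs from compound 2 in one place: 3-(hydroxymethyl)phenyl in place of 4-methylphenyl on an aromatic carbon. The step from compound 1 to compound 2 bears on this change, since it too removes or adds an oxygen-bearing group at the same place, whereas the step from compound 2 to compound 3 shows a neutral exchange. Compound 4 is therefore expected to return part of the way toward the higher number of compound 1, an estimated step of a 3.2-fold higher number from compound 2 to compound 4 (0.50 log units; beyond the scatter). Compound 4 is estimated at 15000 nM, within 4000 nM to 80000 nM.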

Compound 4, half-maximal cytotoxic concentration: 6000 nM
Compound 4: middle estimate off by 2.5-fold (0.40 log units), on the high side; the range from low to high includes it.
By their numbers in this assay, from the lowest: compounds 3, 2 and 4 (each within the scatter of the next). At a limit, above all of these: compound 1.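

In this assay, the steps of a 1.3-fold higher number from compound 2 to compound 4 (0.11 log units; within the scatter) and a 1.3-fold higher number from compound 3 to compound 4 (0.12 log units; within the scatter) both lie within the scatter, so 3-(hydroxymethyl)phenyl cannot be told apart from 4-methylphenyl or 4-fluorophenyl at this position. An oxygen-bearing group on this ring therefore does not by itself go with the high number, since the step of an at least 40-fold lower number from compound 1 to compound 4 (1.61 log units; beyond the scatter) is large and, among the groups shown, only 4-formylphenyl stands apart. That compound's reading is a limit and not a number: the limit of > 245000 nM in this assay, at which 1 of the 4 values shown sits.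

3-(Hydroxymethyl)phenyl differs from 4-formylphenyl both in the group and in where it sits on the ring, and the compounds shown do not separate these two changes. Where a carboxylic acid or an amine on this ring would fall also remains open.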